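Methyl Addition on the Imidazolyl Acylguanidine Core

The compounds below may be only part of what the source reports. "The series", "measured", "known", "first", "only" and "open" are said of these compounds alone.

Two acylguanidines on the shared core have numbers in a functional assay for inhibition of sodium/hydrogen exchanger (Oryctolagus cuniculus) (on this read-out higher numbers stand for weaker inhibition and lower numbers for stronger inhibition), so far. Compound 1 `Cc1c(C(=O)N=C(N)N)cc(S(C)(=O)=O)c(Cl)c1C` gives 58 nM in this assay, and compound 2 `Cc1cc(-n2ccnc2)c(S(C)(=O)=O)cc1C(=O)N=C(N)N` gives 23 nM. Compound 2 thus stands lowest of the two, with compound 1 a higher number, a gap that lies beyond the usual scatter. Compound 3 `Cc1c(C(=O)N=C(N)N)cc(S(C)(=O)=O)c(-n2ccnc2)c1C` is not yet measured. It differs from compound 2 by methyl in place of hydrogen on an aromatic carbon. Within the data shown here, no step between measured compounds that changes one place alone is available, so the size of this change has no precedent. The expected step of a 1.5-fold higher number from compound 2 to compound 3 (0.18 log units; within the scatter) is small and toward weaker inhibition, within or only just beyond the scatter. Compound 3 is estimated at 35 nM in this assay, with a range from 12 nM to 100 nM.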

Compound 3, half-maximal inhibitory concentration: 290 nM
The estimate for compound 3 lay 8.3-fold (0.92 log units) below the measured number, and the stated range ends below it.
By their numbers in this assay, from the lowest: compound 2; then compound 1; then compound 3.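

In this assay, this aromatic carbon, ortho to a 1H-imidazol-1-yl group and ortho to a methyl group, proves highly sensitive to a single added methyl, with a 13-fold higher number from compound 2 to compound 3 (1.10 log units; beyond the scatter), a large step toward weaker inhibition. With the two methyl groups present, 1H-imidazol-1-yl in place of chloro also moves toward weaker inhibition, with a 5.0-fold higher number from compound 1 to compound 3 (0.70 log units; beyond the scatter), so on this substitution pattern the 1H-imidazol-1-yl group offers no gain over chloro. The data shown offer no measurement that accounts for the size of either step.

On these data alone, it remains open whether the loss is specific to methyl or would also appear with fluoro, methoxy or an amine on this carbon. As far as these compounds go, it also remains open whether the same methyl step would hold with chloro in place of the 1H-imidazol-1-yl group.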